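The source may report more compounds than this note shows. Statements on the series, on what has been measured and on what is new or still open speak of the compounds shown alone.

Measured compounds:
- compound 1 `COc1ccc(C(=O)/C=C/c2ccc(OCCNc3ccnc4cc(Cl)ccc34)c(OC)c2)c(OC)c1`: 0.292 h
- compound 2 `COc1cc(/C=C/C(C)=O)ccc1OCc1cn(-c2ccnc3cc(Cl)ccc23)nn1`: 0.123 h
- compound 3 `COc1ccc(C(=O)/C=C/c2ccc(O)c(CN3CCN(c4ccnc5cc(Cl)ccc45)CC3)c2)c(OC)c1`: 0.977 h

In an in vitro ADME assay on microsomes from liver (Homo sapiens) for metabolic stability, read by LC-MS, using NADPH, tested at 1 uM, in the presence of a further agent that is not named here (on this read-out lower numbers stand for a shorter-lived compound and higher numbers for a longer-lived compound), compound 1 sits second highest of the three. Compound 2 gives a number beyond the scatter below it, and compound 3 a number beyond the scatter above it. Compound 4 `COc1cc(/C=C/C(C)=O)ccc1OCCNc1ccnc2cc(Cl)ccc12` has not been measured; it differs from compound 1 in one place: methyl in place of 2,4-dimethoxyphenyl on a carbonyl carbon. Among the compounds with values here, no pair of measured compounds differs in one place, so the size of this step can only be guessed. Compound 2 also carries an acetyl and in this assay compound 2 gives 0.123 h, so a step downward from compound 1 to compound 4 is expected, of modest size, a 1.5-fold lower number from compound 1 to compound 4 (0.16 log units; within the scatter). Compound 4 is therefore estimated at 0.2 h, within 0.08 h to 0.5 h.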

Compound 4, half-life in the Homo sapiens assay: 0.175 h
Estimate against measurement, compound 4: 1.1-fold (0.06 log units) above, within the range that was stated.
By their numbers in the Homo sapiens assay, from the lowest: compounds 2, 4 and 1 (each within the scatter of the next, the first and the last beyond it); then compound 3.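

In the Homo sapiens assay, methyl in place of 2,4-dimethoxyphenyl on a carbonyl carbon gives a 1.7-fold lower number from compound 1 to compound 4 (0.22 log units; within the scatter), so removing that whole aromatic ring leaves the half-life within the scatter. In a physicochemical assay for lipophilicity, read by HPLC, at pH 7.4 (a higher number here means a more lipophilic compound, a lower number a more polar compound), compound 1 gives 4.2 and compound 4 gives 3, and the same change gives a number 1.20 log units lower from compound 1 to compound 4 (beyond the scatter). In this one pair, a large shift in distribution coefficient therefore came without a half-life change beyond the scatter. The compounds shown leave open whether an amine, a carboxylic acid or a longer chain on this carbonyl carbon would shift the half-life beyond the scatter.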